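Benzyl for pyrimidinyl on the piperazine of a sulfamate

A few compounds are considered here, and "the series" means these few. Any claim that something is new, unique, unknown or untested is made for them only; others in the source may bear on it.

Compound 1 `NS(=O)(=O)Oc1ccc2c(c1)CN(C(=O)c1cccc(N3CCN(c4ncccn4)CC3)c1)CC2`: 1.6%
Compound 2 `CCN(Cc1ccc(F)cc1)c1cccc(C(=O)N2CCc3ccc(OS(N)(=O)=O)cc3C2)c1`: 10.9%

Of the compounds shown here, two have been measured in an assay on HEK293 cells for inhibition of Steryl-sulfatase (Homo sapiens), tested at 0.1 uM; on this read-out lower numbers stand for a weaker effect and higher numbers for a stronger effect at the one concentration tested. Compound 1 gives 1.6% and compound 2 gives 10.9%; compound 1 stands lowest of the two numbers, but its nearest neighbour, compound 2, lies within the scatter, so the two readings cannot be told apart. Compound 3 `NS(=O)(=O)Oc1ccc2c(c1)CN(C(=O)c1cccc(N3CCN(Cc4ccccc4)CC3)c1)CC2` is not yet measured. It differs from compound 1 in one place: benzyl in place of pyrimidin-2-yl on an amine nitrogen in a ring. Going by the values given here, no step between measured compounds is known, and nothing shows how a change at this amine nitrogen in a ring affects this assay. The step from compound 1 to compound 3 is therefore expected to be small, with a number 3.4 percentage points higher from compound 1 to compound 3 (within the scatter) as the estimate, and no direction beyond the scatter can be claimed. For compound 3 the expected reading is 5%, within a range from 0% to 20%.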

Compound 3, a percentage reported as inhibition, at one concentration (the size of the read-out at that concentration, not a potency): 0%
The estimate for compound 3 lay 5 percentage points above the measured number, and the stated range covers the measured number.
By their numbers in this assay, from the lowest: compounds 3, 1 and 2 (each within the scatter of the next, the first and the last beyond it).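

In this assay, the first step known at this amine nitrogen in a ring is a number 1.6 percentage points lower from compound 1 to compound 3 (within the scatter), for benzyl in place of pyrimidin-2-yl. This swap replaces a ring with 2 nitrogen and 2 hydrogen-bond acceptors by a ring of carbon only with 0 hydrogen-bond acceptors, yet it leaves the two readings indistinguishable at the one concentration tested. No other measurement bears on why this step stays within the scatter.

Still open, as far as these compounds go, is whether any group on this nitrogen can move the reading beyond the scatter, such as a methyl, a longer alkyl chain or a chain ending in a carboxylic acid. A ring nitrogen carrying only hydrogen would also show how the reading behaves with no aromatic ring at this position.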